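This account rests on a few compounds, and the source may have more. Where it says the series, first, only, none or still open, it means among the compounds named here.

Compound 1 `CN1CCC(C(=O)N2N=CCC2c2ccccc2)CC1` and compound 2 `O=C(C1CCN(c2ccccc2)CC1)N1N=CCC1c1ccccc1` share one core and differ only on an amine nitrogen in a ring. In a physicochemical assay for lipophilicity, read by HPLC, measured as chromatographic lipophilicity, at pH 7.4 (a lower number here means a more polar compound, a higher number a more lipophilic compound), compound 1 gives 1.1, and in this assay compound 2 gives 6.3, the higher of the two numbers. Among the compounds with values here, the single step between them, a number 5.20 log units higher from compound 1 to compound 2 (beyond the scatter), is the only measured step available.

Compound 3 `O=C(c1ccccn1)N1CCC(C(=O)N2N=CCC2c2ccccc2)CC1` comes from compound 2 by one change: (pyridin-2-yl)carbonyl in place of phenyl on an amine nitrogen in a ring. Within the data shown here, no measured pair shows this exact exchange; the step from compound 1 to compound 2 only shows that what sits on this nitrogen can shift this assay by a very large amount. The group that enters carries a ring nitrogen and a carbonyl oxygen that the phenyl lacks, so a large drop in this assay from compound 2 is expected, in the form of a number 3.00 log units lower from compound 2 to compound 3 (beyond the scatter). Compound 3 is therefore estimated at 3.3 in this assay, within a range from 2.4 to 4.2.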

Compound 3, distribution coefficient: 3.1
The estimate for compound 3 lay 0.20 log units above the measured number; low and high end bracket the measured number.
By their numbers in this assay, from the lowest: compound 1; then compound 3; then compound 2.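

In this assay the entering (pyridin-2-yl)carbonyl gives a number 3.20 log units lower from compound 2 to compound 3 (beyond the scatter) and, set against methyl, a number 2.00 log units higher from compound 1 to compound 3 (beyond the scatter) so this group lands between the other two. On this amine nitrogen in a ring, the three groups now give three clearly separate readings, with methyl lowest and phenyl highest, so the position responds in steps and not only between two extremes. No supporting data bear on what sets the size of these steps.

The entering group differs from phenyl by both a carbonyl and a ring nitrogen, and these compounds cannot divide the step between the two. Going by these compounds, how a benzoyl group, which has the carbonyl on a ring of carbon only, or a pyridin-2-yl group without the carbonyl would read on this nitrogen stays open.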